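The source may hold more compounds than are shown below. What is called first, only, known or untested is meant among the compounds shown, and "the series" means these compounds.

Of the compounds shown here, three sharing one core have been measured in a functional assay on A2780 cells (Homo sapiens) for antiproliferative activity, read by resazurin assay, with a stated time of 72 h; on this read-out higher numbers stand for weaker inhibition and lower numbers for stronger inhibition. Compound 1 `CN(Cc1ccccc1)C(=O)c1cc2c(Cc3ccccc3)n[nH]c2cc1O` gives 980 nM, compound 2 `CN(Cc1ccccc1Br)C(=O)c1cc2c(Cc3ccccc3)n[nH]c2cc1O` gives 1200 nM, and compound 3 `CN(Cc1cccc(F)c1)C(=O)c1cc2c(Cc3ccccc3)n[nH]c2cc1O` gives 5000 nM. Compound 3 thus has the highest number of the three, which makes it the weakest inhibitor so far.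

Compound 4 `CN(Cc1ccc(F)cc1)C(=O)c1cc2c(Cc3ccccc3)n[nH]c2cc1O` has not yet been measured. It has the same atoms as compound 3, joined differently: 4-fluorophenyl in place of 3-fluorophenyl on a saturated chain carbon bound to an amide-type nitrogen. In words, 4-fluorophenyl stands in place of 3-fluorophenyl on a saturated chain carbon bound to an amide-type nitrogen.

For the measured compounds named here, no measured step makes this exact change, so the evidence is indirect. Adding a bromo group gave a 1.2-fold higher number from compound 1 to compound 2 (0.09 log units; within the scatter), while adding a fluoro group gave a 5.1-fold higher number from compound 1 to compound 3 (0.71 log units; beyond the scatter). Exchanging the two substituted rings gave a 4.2-fold higher number from compound 2 to compound 3 (0.62 log units; beyond the scatter). These steps suggest that a modest change is the most to expect in this assay. The direction leans towards a lower number, since compound 3 sits at the top of the measured range and compound 1, which carries no fluoro group, gives 980 nM. This lean is weak, and no change beyond the scatter is also possible.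

The estimated change is a 2.0-fold lower number from compound 3 to compound 4 (0.30 log units; within the scatter). For compound 4 the expected value is 2500 nM, with an estimated range from 900 nM to 6500 nM.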

Compound 4, half-maximal inhibitory concentration: 4100 nM
Compound 4: the middle estimate sits 1.6-fold (0.21 log units) below what was measured; low and high end bracket the measured number.
By their numbers in this assay, from the lowest: compounds 1 and 2 (each within the scatter of the next); then compounds 4 and 3 (each within the scatter of the next).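

In this assay, moving the fluoro group from 3-fluorophenyl to 4-fluorophenyl on a saturated chain carbon bound to an amide-type nitrogen gives a 1.2-fold lower number from compound 3 to compound 4 (0.09 log units; within the scatter) and so does not separate these two placements. The higher number seen earlier with compound 3 therefore also appears with the second fluoro placement, as adding this group gives a 4.2-fold higher number from compound 1 to compound 4 (0.62 log units; beyond the scatter) in this comparison, and exchanging 2-bromophenyl for 4-fluorophenyl gives a 3.4-fold higher number from compound 2 to compound 4 (0.53 log units; beyond the scatter) in the other. Nothing available explains why the fluorinated compounds differ from compound 1 and compound 2.

The exchange from 2-bromophenyl to 4-fluorophenyl alters both the halogen and where it sits, so these compounds cannot show which of the two matters. On these data alone, it also remains open whether a different group on this ring, such as methoxy, an amine or a carboxylic acid, would keep the numbers close to those of compound 1 or shift them as the fluoro group does.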